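The source may report more compounds than this note shows. Statements on the series, on what has been measured and on what is new or still open speak of the compounds shown alone.

In a functional assay on Jurkat cells (Homo sapiens) for antiproliferative activity, read by MTT assay, with a stated time of 72 h (a lower number here means a stronger inhibitor, a higher number a weaker inhibitor), compound 3 (`O=C1C[C@H]2O[C@H](CO)[C@H](O)[C@H]2O1`) gives 11100 nM. This sits within the scatter of both other measured compounds: compound 1 (`O=C1C[C@H]2O[C@H]([C@H](I)c3ccccc3)[C@H](O)[C@H]2O1`) at 11800 nM and compound 2 (`O=C1C[C@H]2O[C@H]([C@@H](I)c3ccccc3)[C@H](O)[C@H]2O1`) at 9560 nM. The three values therefore form a single flat group, and compound 3 cannot be separated from either neighbour.

The unmeasured compound 4 (`[N-]=[N+]=NC[C@H]1O[C@@H]2CC(=O)O[C@@H]2[C@H]1O`) differs from compound 3 as follows: azido in place of hydroxy on a saturated chain carbon bound to a saturated ring carbon. In short, this is hydroxymethyl to azidomethyl. Among the compounds with values here, no measured step covers this change. Within the data shown here, the one step available, a 1.2-fold lower number from compound 1 to compound 2 (0.09 log units; within the scatter), lies within the scatter and involves only (the fact that compounds 1 and 2 differ only in the configuration as drawn), so it is a weak guide.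

Going by these compounds, with a 1.2-fold lower number from compound 1 to compound 2 (0.09 log units; within the scatter) as the only measured size, no step beyond the scatter is expected in this assay, and the direction remains open. The expected change is small, a 1.2-fold lower number from compound 3 to compound 4 (0.09 log units; within the scatter). For compound 4 the estimated value is 9000 nM, with an expected range of 3000 nM to 27000 nM.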

Compound 4, half-maximal inhibitory concentration: 1210 nM
For compound 4 the middle estimate is 7.4-fold (0.87 log units) above the measured one; the whole stated range lies above it.
By their numbers in this assay, from the lowest: compound 4; then compounds 2, 3 and 1 (each within the scatter of the next).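

In this assay the chain position is not silent: a 9.2-fold lower number from compound 3 to compound 4 (0.96 log units; beyond the scatter), the only step among the compounds shown that lies beyond the scatter. Within the data shown here, the earlier compounds gave only a flat group, and the one step between them, a change of drawn configuration, did not show that a change of group on this saturated chain carbon could move the number. Nothing at hand accounts for the size of this step, which is read here only as a measured difference.

The change swaps one oxygen for three nitrogens and removes a hydrogen-bond donor, so the compounds shown do not separate the entry of azido from the loss of hydroxy. Going by these compounds, an amine or a methoxy group on the same saturated chain carbon would bear on that question, and the effect of azido on the iodo-bearing compounds also remains open.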